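Three Silent Analogues and a Hydroxyphenyl Newcomer

A few compounds are considered here, and "the series" means these few. Any claim that something is new, unique, unknown or untested is made for them only; others in the source may bear on it.

In a functional assay on EC9706 cells (Homo sapiens) for cytotoxicity, read by MTT assay, with a stated time of 72 h (a higher number here means a weaker inhibitor, a lower number a stronger inhibitor), three close relatives of a shared core have been tested. Compound 1 `Cc1cccc(NC(=O)CSC(=S)N[C@H]2CCOC2=O)c1` gives only a limit, > 128000 nM, rather than a number. Compound 2 `O=C(CSC(=S)N[C@H]1CCOC1=O)Nc1ccccc1` likewise reaches only the limit of > 128000 nM. Compound 3 `O=C(CSC(=S)N[C@H]1CCOC1=O)Nc1ccccc1Cl` also stops at the limit of > 128000 nM. With the limit of > 128000 nM in this assay, at which 3 of the 3 values shown sit, every comparison among them is blind: the step that the two limits leave unreadable from compound 1 to compound 2, the step that the two limits leave unreadable from compound 1 to compound 3 and the step that the two limits leave unreadable from compound 2 to compound 3 cannot be sized, so nothing shows whether exchanging groups on the amide-type nitrogen moves the number up or down.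

Compound 4 `O=C(CSC(=S)N[C@H]1CCOC1=O)Nc1ccc(O)cc1` takes the next step from compound 3: 4-hydroxyphenyl in place of 2-chlorophenyl on an amide-type nitrogen. Among the measured compounds shown here, no measured pair tells how a 4-hydroxyphenyl behaves here; the only guidance is that three different aryl groups on the same nitrogen all gave only a limit. The change is therefore expected to be a number no higher from compound 3 to compound 4 (the limit leaves the size open), meaning no detectable movement. Compound 4 is accordingly estimated to lie near 128000 nM, somewhere between 30000 nM and 500000 nM, with a strong chance that only a limit is reported once more.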

Compound 4, half-maximal inhibitory concentration: > 128000 nM
Compound 4: a limit, no number (the forecaster's own chance of this, stated with the estimate: 75%); the middle value lies on the limit itself.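

Compound 4 also gives only a limit, so its steps from compound 1, compound 2 and compound 3 cannot be read, and none of them can be sized: the limit of > 128000 nM in this assay, at which 4 of the 4 values shown sit.

The compounds shown leave open whether any group on the amide-type nitrogen of the shared core can give a true number in this assay.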